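Swapping a Chloro for an Amino Group: What to Expect

The compounds below may be only part of what the source reports. "The series", "measured", "known", "first", "only" and "open" are said of these compounds alone.

Compound 1 `ClCc1ccc(Cn2cnc3c(Cl)ncnc32)cc1` gives 270 nM in a functional assay on SF-295 cells (Homo sapiens) for cytotoxicity, read by sulforhodamine B assay, with a stated time of 48 h; a lower number here means a stronger inhibitor of growth, a higher number a weaker inhibitor of growth.
Compound 2 `ClCc1ccccc1Cn1cnc2c(Cl)nc(Cl)nc21` gives 1900 nM in this assay.
Compound 3 `ClCc1cccc(Cn2cnc3c(Cl)ncnc32)c1` gives 3230 nM in this assay.

Among these three numbers, compound 2 stands second highest. Its nearest neighbour is compound 3, and the gap between compound 2 and compound 3 lies within the usual scatter of such measurements, so no order between the two can be read. Compound 1 is the furthest away, and the gap from compound 2 to compound 1 is beyond the scatter, with compound 1 giving the lower number. Within the data shown here, no two of these measured compounds differ in only one place, so the data give no single-change step to lean on.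

Compound 4 `Nc1nc(Cl)c2ncn(Cc3ccccc3CCl)c2n1` differs from compound 2 in one place: amino in place of chloro on an aromatic carbon. Among the measured compounds shown here, no measured pair shows this exchange, so there is no direct precedent within the set. The step in this assay from compound 2 is therefore expected to be small, most likely not beyond the scatter, and if anything slightly upward, as a 1.3-fold higher number from compound 2 to compound 4 (0.12 log units; within the scatter). Compound 4 is estimated at 2500 nM, with a range from 800 nM to 8000 nM.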

Compound 4, concentration for 50% growth inhibition: 7410 nM
The estimate for compound 4 lay 3.0-fold (0.47 log units) below the measured number, within the range that was stated.
By their numbers in this assay, from the lowest: compound 1; then compounds 2 and 3 (each within the scatter of the next); then compound 4.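

In this assay, amino in place of chloro on this aromatic carbon, between two ring nitrogen atoms, gives a 3.9-fold higher number from compound 2 to compound 4 (0.59 log units; beyond the scatter), so the carbon is not indifferent to this change. Among these compounds, this is the first single-change step in the set, and it goes towards weaker growth inhibition, although it rests on this one pair alone. Nothing available explains why the number moves in this direction.

As far as these compounds go, it remains open whether another group on this carbon, such as methoxy or methylamino, would stay close to compound 2 or move further from it. From the compounds shown here alone, it is also open whether amino here would give a step of similar size when paired with the side chain of compound 1.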